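The source may hold more compounds than are shown below. What is called first, only, known or untested is meant among the compounds shown, and "the series" means these compounds.

In a functional assay on blood (Homo sapiens), with a stated time of 60 min, in the presence of a further agent that is not named here (a higher number here means that more compound is needed for the effect, a lower number that less compound is needed), compound 1 `O=C(O)C1(S(=O)(=O)c2ccc(Oc3ccc(OC(F)(F)F)cc3)cc2)CCC2(CCNCC2)C1`, with hydroxy on its carbonyl carbon, gives 1800 nM. Compound 2 `O=C(Nc1nccs1)C1(S(=O)(=O)c2ccc(Oc3ccc(OC(F)(F)F)cc3)cc2)CCC2(CCNCC2)C1` gives > 15000 nM, which is a limit of the assay and not a number. Compound 2 therefore has no exact place on the scale, only the position described by the limit of > 15000 nM in this assay, at which 1 of the 2 values shown sits.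

Compound 3 `O=C1CN(C(=O)C2(S(=O)(=O)c3ccc(Oc4ccc(OC(F)(F)F)cc4)cc3)CCC3(CCNCC3)C2)CCN1` has not yet been measured. It differs from compound 2 in one place, on a carbonyl carbon whose other neighbour is a saturated ring carbon, where 3-oxopiperazin-1-yl stands in place of (1,3-thiazol-2-yl)amino (3-oxopiperazin-1-yl in place of (1,3-thiazol-2-yl)amino on a carbonyl carbon).

Among the compounds with values here, no measured step exchanges one of these two groups for the other, so the evidence is indirect. Compound 3 also lacks the hydroxy, so, going by an at least 8.3-fold higher number from compound 1 to compound 2 (0.92 log units; beyond the scatter), its number in this assay is expected to stay high, near the limit of compound 2. The expected change is a number no higher from compound 2 to compound 3 (the limit leaves the size open), so no clear shift in either direction is estimated, and a further limit reading is quite possible. For compound 3 the estimated value is 15000 nM, with an expected range from 4000 nM to 50000 nM.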

Compound 3, half-maximal effective concentration: 7500 nM
Compound 3: middle estimate off by 2.0-fold (0.30 log units), on the high side; measured number inside the range.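

Compound 3 shows that losing the hydroxy on this carbonyl carbon does not have to push the reading out of range: in this assay, compound 3 gives 7500 nM, a true number, and the cost of the exchange can now be sized as a 4.2-fold higher number from compound 1 to compound 3 (0.62 log units; beyond the scatter). Compound 2, by contrast, holds only a limit of the assay and not a number: the limit of > 15000 nM in this assay, at which 1 of the 3 values shown sits.

Measured against that limit, the exchange of groups gives an at least 2.0-fold lower number from compound 2 to compound 3 (0.30 log units; that floor lies within the scatter), so the true gap could be larger, but as printed it cannot be told apart from the scatter, and 3-oxopiperazin-1-yl cannot yet be called better than (1,3-thiazol-2-yl)amino at this place.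

The compounds shown leave open whether a small group on the same carbonyl carbon, such as a plain amino group or a methoxy group, would stay closer to compound 1 than compound 3 does. They also leave open what the ring carbonyl of 3-oxopiperazin-1-yl contributes, a question that a piperazin-1-yl group, the same ring without that carbonyl, could address.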